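The source may report more compounds than this note shows. Statements on the series, on what has been measured and on what is new or still open speak of the compounds shown alone.

Within the data shown here, compound 2 `Cn1cc(-c2cnc(N)c(Oc3ccc(C(=O)Nc4cccc(Cl)c4)cc3)n2)cn1` gives 21700 nM in a functional assay on U-87MG ATCC cells for inhibition, with U-87 MG (Homo sapiens) as the target, read by MTT assay, with a stated time of 72 h (on this read-out higher numbers stand for weaker inhibition and lower numbers for stronger inhibition), the lowest of the two numbers recorded; its nearest neighbour, compound 1 `Cn1cc(-c2cnc(N)c(Oc3ccc(C(=O)Nc4ccccc4Cl)cc3)n2)cn1`, gives 44800 nM in this assay, and the only step recorded, a 2.1-fold lower number from compound 1 to compound 2 (0.31 log units; beyond the scatter), is modest. Compound 3 `Cn1cc(-c2cnc(N)c(Oc3ccc(C(=O)Nc4ccc(Cl)cn4)cc3)n2)cn1` differs from compound 2 by 5-chloropyridin-2-yl in place of 3-chlorophenyl on an amide-type nitrogen. Among the measured compounds shown here, no measured step concerns this exchange, so nothing in the data points to a direction. Compound 3 is therefore expected to stay close to compound 2, a step of a 1.0-fold higher number from compound 2 to compound 3 (0.01 log units; within the scatter), within the scatter. The estimate for compound 3 is 22000 nM, with a range from 8000 nM to 60000 nM.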

Compound 3, half-maximal inhibitory concentration: 22200 nM
Compound 3: middle estimate off by 1.0-fold (0.00 log units), on the low side; the measured number falls inside the stated range.
By their numbers in this assay, from the lowest: compounds 2, 3 and 1 (each within the scatter of the next, the first and the last beyond it).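

At this position on the amide-type nitrogen, 5-chloropyridin-2-yl can take the place of 3-chlorophenyl, bringing a ring nitrogen and a hydrogen-bond acceptor, with a 1.0-fold higher number from compound 2 to compound 3 (0.01 log units; within the scatter) in this assay. Against 2-chlorophenyl the same group gives a 2.0-fold lower number from compound 1 to compound 3 (0.30 log units; within the scatter), which also stays within the scatter, at its edge. Nothing measured here accounts for either step. The compounds shown leave open how a plain phenyl, a cyclohexyl or a longer alkyl chain would read on this nitrogen, and whether the chlorine is needed at all.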